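A few compounds are considered here, and "the series" means these few. Any claim that something is new, unique, unknown or untested is made for them only; others in the source may bear on it.

Measured so far:
compound 1 `CCCOC(=O)C1=C(C)NC(=O)NC1c1cccs1` — 43%
compound 2 `CCCOC(=O)C1=C(C)NC(=O)NC1c1ccsc1` — 44%
compound 3 `CCCOC(=O)C1=C(C)N(C)C(=O)NC1c1cccs1` — 9%

In an assay on membranes from CHO cells for displacement of a labelled ligand from adenosine receptor A1 (Homo sapiens), read by scintillation counting, with a stated time of 60 min, tested at 1 uM (on this read-out higher numbers stand for more inhibition at the one concentration tested (going by the name of the read-out) and lower numbers for less inhibition), compound 3 gives 9%, the lowest of the three numbers; the step of a number 34 percentage points lower from compound 1 to compound 3 (beyond the scatter) is large and beyond the scatter, and compound 2 sits further still. Compound 4 `CCCOC(=O)C1=C(C)N(C)C(=O)NC1c1ccsc1` differs from compound 3 by thiophen-3-yl in place of thiophen-2-yl on a saturated ring carbon. Among the measured compounds shown here, the single measured step of this kind, a number 1 percentage points higher from compound 1 to compound 2 (within the scatter), lies within the scatter, so for compound 4 no step beyond the scatter is expected in this assay in either direction. Compound 4 is therefore estimated at 10%, with a range from 0% to 22%, which corresponds to an expected step of a number 1 percentage points higher from compound 3 to compound 4 (within the scatter).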

Compound 4, a percentage reported as inhibition, at one concentration (the size of the read-out at that concentration, not a potency): 2%
Compound 4: the middle estimate sits 8 percentage points above what was measured; measured number inside the range.
By their numbers in this assay, from the lowest: compounds 4 and 3 (each within the scatter of the next); then compounds 1 and 2 (each within the scatter of the next).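

In this assay the swap of thiophen-2-yl for thiophen-3-yl on the saturated ring carbon now reads on the core with methyl on the amide-type nitrogen, a number 7 percentage points lower from compound 3 to compound 4 (within the scatter), and the change stays within the scatter on both cores: the same change on two cores in this assay, a number 1 percentage points higher (within the scatter) from compound 1 to compound 2 and a number 7 percentage points lower (within the scatter) from compound 3 to compound 4, 8 percentage points apart, within the scatter of two such steps. Methyl in place of hydrogen on that nitrogen now also reads with thiophen-3-yl, a number 42 percentage points lower from compound 2 to compound 4 (beyond the scatter), so the large drop recurs with either thiophene: the same change on two cores in this assay, a number 34 percentage points lower (beyond the scatter) from compound 1 to compound 3 and a number 42 percentage points lower (beyond the scatter) from compound 2 to compound 4, 8 percentage points apart, within the scatter of two such steps.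

Open, going by these compounds, is whether an ethyl group or a longer chain on that nitrogen gives a similar drop. Also open, on these data alone, is how a phenyl or furan-3-yl group on the saturated ring carbon compares with the two thiophenes.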